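A few compounds are considered here, and "the series" means these few. Any claim that something is new, unique, unknown or untested is made for them only; others in the source may bear on it.

Measured in a functional assay on MGC-803 cells (Homo sapiens) for antiproliferative activity, read by MTT assay, with a stated time of 48 h; on this read-out lower numbers stand for stronger inhibition and higher numbers for weaker inhibition:
- compound 1 `COc1ccc(CN(C(=O)CCCSc2nc3ccccc3o2)c2cc(OC)c(OC)c(OC)c2)cc1`: 1290 nM
- compound 2 `COc1ccc(CN(C(=O)CSc2nncs2)c2cc(OC)c(OC)c(OC)c2)cc1`: 1150 nM

Compound 2 has only compound 1 to stand against, and the two values lie within the scatter of each other. Compound 3 `COc1ccc(CN(C(=O)CSc2nc3ccccc3o2)c2cc(OC)c(OC)c(OC)c2)cc1` differs from compound 2 in one place: 1,3-benzoxazol-2-yl in place of 1,3,4-thiadiazol-2-yl on a sulfur. In words, 1,3-benzoxazol-2-yl comes in place of 1,3,4-thiadiazol-2-yl on a sulfur. For the measured compounds named here, one measured step bears on this, a 1.1-fold lower number from compound 1 to compound 2 (0.05 log units; within the scatter). Compound 1 already carries the incoming group, but as 2-((1,3-benzoxazol-2-yl)sulfanyl)ethyl, so that step does not isolate the present change. Going by the values given here, with this single step as the only guide, no change beyond the scatter is expected in this assay. The expected step is a 1.0-fold lower number from compound 2 to compound 3 (0.02 log units; within the scatter). Compound 3 is estimated at 1100 nM, with an expected range of 450 nM to 2600 nM.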

Compound 3, half-maximal inhibitory concentration: 450 nM
Compound 3: the middle estimate sits 2.4-fold (0.39 log units) above what was measured; the range from low to high includes it.
By their numbers in this assay, from the lowest: compound 3; then compounds 2 and 1 (each within the scatter of the next).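

In this assay, the group on the sulfur makes a measurable difference: 1,3-benzoxazol-2-yl in place of 1,3,4-thiadiazol-2-yl gives a 2.6-fold lower number from compound 2 to compound 3 (0.41 log units; beyond the scatter), while (1,3-benzoxazol-2-yl)sulfanyl in place of 2-((1,3-benzoxazol-2-yl)sulfanyl)ethyl on the saturated chain carbon bound to the carbonyl carbon gives a 2.9-fold lower number from compound 1 to compound 3 (0.46 log units; beyond the scatter). The earlier pair, compound 1 and compound 2, differed in both features at once and stayed within the scatter, so it concealed two separate steps that run in opposite directions. Nothing measured here accounts for either step.

Going by these compounds, it remains open whether 1,3-benzoxazol-2-yl is matched by other fused rings, such as 1,3-benzothiazol-2-yl. On these data alone, it is also open whether a chlorine or an amine on the 1,3-benzoxazol-2-yl group would move the number further.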